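The source may report more compounds than this note shows. Statements on the series, on what has been measured and on what is new or still open speak of the compounds shown alone.

In a functional assay on HepG2 cells (Homo sapiens), read by MTT assay, with a stated time of 48 h (a lower number here means a stronger inhibitor, a higher number a weaker inhibitor), compound 1 (`CCn1c(C(=O)NCCN(C)C)ccc1C(CC)(CC)c1ccc(OCC(O)C(C)(C)C)c(C)c1`) gives 870 nM and compound 2 (`CCN(CC)CCCNC(=O)c1ccc(C(CC)(CC)c2ccc(OCC(O)C(C)(C)C)c(C)c2)n1CC`) gives 1100 nM. These two are close, with a 1.3-fold higher number from compound 1 to compound 2 (0.10 log units; within the scatter). Compound 3 (`CCn1c(C(=O)NCC(OC)OC)ccc1C(CC)(CC)c1ccc(OCC(O)C(C)(C)C)c(C)c1`) stands highest of the three at 23200 nM, which makes it the weakest inhibitor of the set.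

The next structure is compound 4 (`CCn1c(C(=O)NCCN)ccc1C(CC)(CC)c1ccc(OCC(O)C(C)(C)C)c(C)c1`). It has aminomethyl in place of dimethoxymethyl on a saturated chain carbon bound to an amide-type nitrogen.

Within the data shown here, two measured steps bear on this change, a 27-fold higher number from compound 1 to compound 3 (1.43 log units; beyond the scatter) and a 21-fold higher number from compound 2 to compound 3 (1.32 log units; beyond the scatter). Both are large and both arrive at the dimethoxymethyl group, whereas compound 4 leaves that group, so the change runs the opposite way. Among the measured compounds shown here, no measured compound carries aminomethyl itself, so a full return to the level of compound 1 is not assured.

A large step towards a lower number is therefore expected, estimated as a 15-fold lower number from compound 3 to compound 4 (1.19 log units; beyond the scatter). For compound 4 the estimated value is 1500 nM, with an expected range of 500 nM to 6000 nM.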

Compound 4, half-maximal inhibitory concentration: 176 nM
Compound 4: middle estimate off by 8.5-fold (0.93 log units), on the high side, and the stated range ends above it.
By their numbers in this assay, from the lowest: compound 4; then compounds 1 and 2 (each within the scatter of the next); then compound 3.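

In this assay the change to 2-aminoethyl gives a 130-fold lower number from compound 3 to compound 4 (2.12 log units; beyond the scatter) and does more than recover what the dimethoxymethyl group lost, since it also gives a 4.9-fold lower number from compound 1 to compound 4 (0.69 log units; beyond the scatter) and a 6.3-fold lower number from compound 2 to compound 4 (0.80 log units; beyond the scatter) when set against the compounds whose chains end in substituted amines. The close values of compound 1 and compound 2 therefore did not mean that the end of this chain could vary freely. An unsubstituted amino group gives the lowest number of the four. The data shown offer no evidence on why this change has such a large effect.

The series leaves open how the number changes between amino and dimethylamino, which a methylamino group on the same chain could show. It also leaves open whether an amino group on a longer chain, or a hydroxyl group in its place, would keep the low number of compound 4.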